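Microsomal stability notes: the step from compound 3 to compound 4

The source may hold more compounds than are shown below. What is called first, only, known or untested is meant among the compounds shown, and "the series" means these compounds.

In an ADME assay on microsomes from liver (Homo sapiens) for metabolic stability, read by LC-MS, tested at 1 uM (on this read-out lower numbers stand for slow clearance and higher numbers for fast clearance), compound 3 `NCCOc1ccc([C@H]2CC[C@]3(CC2)OOC2(O3)C3CC4CC(C3)CC2C4)cc1` reaches only a limit of the assay, < 7 mL.min-1.g-1. Compound 1 `NCCOCCOc1ccc([C@H]2CC[C@]3(CC2)OOC2(O3)C3CC4CC(C3)CC2C4)cc1` likewise returns a limit, < 7 mL.min-1.g-1. Compound 2 `N[C@H]1CC[C@H](Oc2ccc([C@H]3CC[C@]4(CC3)OOC3(O4)C4CC5CC(C4)CC3C5)cc2)CC1` also stands at a limit, < 7 mL.min-1.g-1. Hence (the limit of < 7 mL.min-1.g-1 in this assay, at which 3 of the 3 values shown sit), and the steps a step that the two limits leave unreadable from compound 1 to compound 2, a step that the two limits leave unreadable from compound 1 to compound 3 and a step that the two limits leave unreadable from compound 2 to compound 3 cannot be sized; none of them bears a readable size on the change at hand. Compound 4 `c1cc([C@H]2CC[C@]3(CC2)OOC2(O3)C3CC4CC(C3)CC2C4)ccc1OCCOC1CCNCC1` differs from compound 3 as follows: (piperidin-4-yl)oxy in place of amino on a saturated chain carbon, two bonds along the chain from an oxygen on an aromatic ring. Since compound 3 sits at the limit < 7 mL.min-1.g-1, the expected step of a number no lower from compound 3 to compound 4 (the limit leaves the size open) is taken as none beyond the scatter. Compound 4 is therefore estimated at 7 mL.min-1.g-1, within 3 mL.min-1.g-1 to 20 mL.min-1.g-1.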

Compound 4, intrinsic clearance in microsomes: < 7 mL.min-1.g-1
Compound 4: only a limit was reported; the forecaster's own chance of this, stated with the estimate: 55%; the middle value lies on the limit itself.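

No step among compound 1, compound 2, compound 3 and compound 4 can be read in this assay: the limit of < 7 mL.min-1.g-1 in this assay, at which 4 of the 4 values shown sit.

How far clearance actually differs among these four compounds, or whether it differs at all, stays open.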